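The source may report more compounds than this note shows. Statements on the series, on what has been measured and on what is new or still open speak of the compounds shown alone.

Measured so far in a functional assay on MDA-MB-231 cells (Homo sapiens) for antiproliferative activity, read by MTT assay, with a stated time of 72 h; a higher number here means a weaker inhibitor, a lower number a stronger inhibitor:

- Compound 1, `Cc1ccc(C(=O)Nc2cccc(C(F)(F)F)c2)cc1C#Cc1nn(CC2CCN(C)C2)c2ncnc(N)c12`: 41 nM
- Compound 2, `Cc1ccc(NC(=O)c2cccc(C(C)(C)C)c2)cc1C#Cc1nn([C@H]2CC[C@H](O)CC2)c2ncnc(N)c12`: 30 nM
- Compound 3, `Cc1ccc(NC(=O)c2ccc(C)c(C(F)(F)F)c2)cc1C#Cc1nn(C[C@H](C)CO)c2ncnc(N)c12`: 43 nM

All three share the same core and the same alkyne-linked amide scaffold, and differ in the group on the amide and in the substituent carried on the core. In this assay compound 2 gives the lowest of the three numbers, but its gaps to compound 1 and to compound 3 both fall within the usual scatter, so the three compounds cannot be told apart on these data; none can be called the most potent.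

Compound 4, `Cc1ccc(NC(=O)c2ccc(Cl)c(C(F)(F)F)c2)cc1C#Cc1nn([C@H]2CC[C@H](O)CC2)c2ncnc(N)c12`, has not yet been measured. It keeps the hydroxycyclohexyl group on the core of compound 2 and changes only the aryl on the amide: 4-chloro-3-(trifluoromethyl)phenyl in place of 3-(tert-butyl)phenyl on a carbonyl carbon. Compounds 1 and 3, which also carry a trifluoromethyl-bearing aryl on the amide, sit close to compound 2 in this assay, so no step beyond the scatter is expected in either direction for the change from compound 2 to compound 4. Compound 4 is therefore estimated at 35 nM, with a plausible range of 15 nM to 90 nM, which corresponds to an expected step of a 1.2-fold higher number from compound 2 to compound 4 (0.07 log units; within the scatter).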

Compound 4, half-maximal inhibitory concentration: 16 nM
Estimate against measurement, compound 4: 2.2-fold (0.34 log units) above, within the range that was stated.
By their numbers in this assay, from the lowest: compounds 4, 2, 1 and 3 (each within the scatter of the next, the first and the last beyond it).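

Within the data shown here, this is the first comparison here in which only one place changes, since the earlier compounds differed in both the amide group and the substituent on the core. With the hydroxycyclohexyl group held constant in this assay, replacing 3-(tert-butyl)phenyl with 4-chloro-3-(trifluoromethyl)phenyl on a carbonyl carbon gives a 1.9-fold lower number from compound 2 to compound 4 (0.27 log units; within the scatter), so this all-carbon substituent pattern and this halogen-bearing one cannot be told apart at this position. Both groups contain one six-membered aromatic ring of carbon only and no hydrogen-bond donors or acceptors, so the pair tests a change in the substituents on that ring rather than in the ring itself, and nothing available here bears on why the number differs by the amount it does.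

Still open, going by these compounds, is whether the chlorine or the trifluoromethyl group contributes more to the value of compound 4, and whether the same swap would give a similar step with another group on the core. It is also unknown how this position would respond to an aryl group carrying an amine or a carboxylic acid, or to a saturated ring such as cyclohexyl.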